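The compounds below may be only part of what the source reports. "The series", "measured", "known", "first", "only" and "open" are said of these compounds alone.

In a functional assay on SK-OV-3 cells (Homo sapiens) for inhibition, read by MTT assay (on this read-out lower numbers stand for stronger inhibition and higher numbers for weaker inhibition), three compounds sharing one core have been measured. Compound 1 `COc1ccc(/C=C2\c3cc(OC)c(OC)c(OC)c3CC[C@@H]2O)cc1C#N` gives 20 nM, compound 2 `COc1ccc(/C=C2\c3cc(OC)c(OC)c(OC)c3CC[C@@H]2O)cc1O` gives 1060 nM and compound 3 `COc1ccc(/C=C2\c3cc(OC)c(OC)c(OC)c3CC[C@H]2O)cc1C#N` gives 600 nM. Compound 3 lies within the scatter of compound 2, and both sit far from compound 1. The gap to compound 3 is a 30-fold higher number from compound 1 to compound 3 (1.48 log units; beyond the scatter), and what is known about it is the fact that compounds 1 and 3 differ only in the configuration as drawn.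

Compound 4 `COc1ccc(/C=C2\c3cc(OC)c(OC)c(OC)c3CC[C@H]2O)cc1C(N)=O` keeps the configuration of compound 3 and changes one group: carbamoyl in place of cyano on an aromatic carbon. Among the measured compounds shown here, only one measured step touches the cyano group, the large 53-fold higher number from compound 1 to compound 2 (1.72 log units; beyond the scatter). It brings in hydroxy rather than carbamoyl, however, and it was measured in the other configuration, so it is only a loose guide. Compound 3 already stands far from compound 1, so a smaller move in the same direction is expected here. The expected change is a 3.0-fold higher number from compound 3 to compound 4 (0.48 log units; beyond the scatter), towards weaker inhibition. For compound 4 the estimated value is 1800 nM, with an expected range of 500 nM to 6500 nM.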

Compound 4, half-maximal inhibitory concentration: 1920 nM
Beside the measured number, compound 4's estimate is 1.1-fold (0.03 log units) below it; the range from low to high includes it.
By their numbers in this assay, from the lowest: compound 1; then compounds 3, 2 and 4 (each within the scatter of the next, the first and the last beyond it).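

In this assay, the aromatic carbon ortho to a methoxy group still responds to a change of group in the configuration of compound 3, with carbamoyl in place of cyano giving a 3.2-fold higher number from compound 3 to compound 4 (0.51 log units; beyond the scatter). The earlier compounds shown here showed a change at this position only in the other configuration, and there with hydroxy, so the step shows that the weaker configuration does not remove the difference between groups here. Compounds 3 and 4 share one configuration, so this modest step involves no change in configuration, unlike the larger gap, about which only one thing is known: the fact that compounds 1 and 3 differ only in the configuration as drawn

As far as these compounds go, what carbamoyl gives in the configuration of compound 1 remains open, so it cannot be said whether the step carries over. From the compounds shown here alone, how a carboxylic acid or an amine at this position would compare with cyano is also open.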